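The source may hold more compounds than are shown below. What is called first, only, known or untested is meant among the compounds shown, and "the series" means these compounds.

In a functional assay on CCRF-CEM cells (Homo sapiens) for inhibition (a higher number here means a weaker inhibitor, a lower number a stronger inhibitor), compound 1 `O=C1CCCCC/C1=C\c1ccccc1` gives 110000 nM and compound 2 `Cc1cccc(/C=C2\CCCCCC2=O)c1` gives 170000 nM. Going by the values given here, these are the only two measurements so far, and they lie within the usual scatter of each other, so compound 2 cannot be separated from compound 1. Compound 3 `O=C1CCCCC/C1=C\c1cccc([N+](=O)[O-])c1` has nitro in place of methyl on an aromatic carbon, meta to a group of 9 heavy atoms: nitro in place of methyl on an aromatic carbon. Among the compounds with values here, only one measured step bears on this change, a 1.5-fold higher number from compound 1 to compound 2 (0.19 log units; within the scatter), which is methyl in place of hydrogen on an aromatic carbon. It involves no nitro, so it offers only limited guidance. With nothing beyond the scatter seen so far, no step beyond the scatter is expected in this assay, in either direction. The expected step is a 1.3-fold lower number from compound 2 to compound 3 (0.12 log units; within the scatter). The estimate for compound 3 is 130000 nM, with an expected range from 50000 nM to 300000 nM.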

Compound 3, half-maximal inhibitory concentration: 30100 nM
Compound 3: the middle estimate sits 4.3-fold (0.64 log units) above what was measured, and the stated range ends above it.
By their numbers in this assay, from the lowest: compound 3; then compounds 1 and 2 (each within the scatter of the next).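

In this assay, the place on the aromatic ring meta to a group of 9 heavy atoms now proves able to shift the number beyond the scatter: nitro in place of methyl gives a 5.6-fold lower number from compound 2 to compound 3 (0.75 log units; beyond the scatter) and nitro in place of hydrogen gives a 3.7-fold lower number from compound 1 to compound 3 (0.56 log units; beyond the scatter) at the same place. Both steps are modest but run the same way, so compound 3 has the lowest number of the three, whereas methyl in place of hydrogen gave only a 1.5-fold higher number from compound 1 to compound 2 (0.19 log units; within the scatter) and cannot be told apart from no change. Nothing measured here accounts for what nitro does at this place.

On these data alone, whether a step of this kind belongs to nitro alone or would also come with an amine, a carboxylic acid or a nitrile at this place stays open. So does whether nitro elsewhere on the aromatic ring would give a similar step.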